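The source may report more compounds than this note shows. Statements on the series, on what has been measured and on what is new or still open speak of the compounds shown alone.

Three compounds have been measured in an assay on V79 cells for inhibition of cytochrome P450 11B1, mitochondrial (Homo sapiens), read by HTRF, with a stated time of 1 h; a higher number here means a weaker inhibitor, a lower number a stronger inhibitor:

compound 1 `Cn1c(-c2cccnc2)nc2ccc(F)cc21`, which gives 677 nM
compound 2 `Fc1cc2nc(-c3cccnc3)n(C3CC3)c2cc1F`, which gives 370 nM
compound 3 `Cc1ccncc1-c1nc2cc(F)c(F)cc2n1C1CC1`, which gives 723 nM

Compound 3 has the highest of the three numbers, but none of the gaps is large. Its nearest neighbour is compound 1, whose number sits within the scatter of repeated measurements. Compound 2 and compound 3 differ in a single place, a methyl in place of hydrogen on an aromatic carbon, and the step of a 2.0-fold higher number from compound 2 to compound 3 (0.29 log units; within the scatter) also stays within the scatter. So far, then, no single change among these compounds has moved the number beyond what repeat measurements would show.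

Compound 4 `Cc1c(F)cncc1-c1nc2cc(F)c(F)cc2n1C1CC1` is the next compound to be measured. It differs from compound 3 by fluoro in place of hydrogen on an aromatic carbon: the new fluorine sits on an aromatic carbon of a six-membered aromatic ring with one nitrogen, ortho to a methyl group, two atoms from the ring nitrogen, and meta to a large group. For the measured compounds named here, no measured step here adds a fluorine to that ring; the only single-change step, a 2.0-fold higher number from compound 2 to compound 3 (0.29 log units; within the scatter), concerns a methyl and is small. There is thus no firm guide, and the expectation is for no step beyond the scatter, with perhaps a slight drift toward a higher number.

Compound 4 is therefore expected to give about 900 nM in this assay, with a likely range from 300 nM to 2700 nM. That estimate means an expected step of a 1.2-fold higher number from compound 3 to compound 4 (0.10 log units; within the scatter).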

Compound 4, half-maximal inhibitory concentration: 258 nM
For compound 4 the middle estimate is 3.5-fold (0.54 log units) above the measured one; measured number below the stated range.
By their numbers in this assay, from the lowest: compounds 4, 2, 1 and 3 (each within the scatter of the next, the first and the last beyond it).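

Placing fluoro in place of hydrogen on an aromatic carbon of the six-membered aromatic ring with one nitrogen, ortho to a methyl group, gives in this assay a 2.8-fold lower number from compound 3 to compound 4 (0.45 log units; beyond the scatter), the first single change in this set to move the number beyond what repeat measurements would show. This position is therefore not indifferent to substitution: one added heavy atom is enough to make compound 4 a modestly stronger inhibitor than compound 3. Nothing available here explains why the number falls.

The compounds shown leave open whether this drop belongs to fluorine in particular, or whether another group on the same carbon, such as chloro, methoxy or an amine, would shift the number to a similar degree or in the opposite direction. For the compounds shown here, they also leave open whether fluoro would produce a step of this size without the neighbouring methyl group, as this one pair is the only test of the change.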